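The source may report more compounds than this note shows. Statements on the series, on what has been measured and on what is new or still open speak of the compounds shown alone.

Working notes on the series. Among the compounds with values here, in an assay on HEK293 cells for agonist activity at Toll-like receptor 8 (Homo sapiens), read by reporter gene assay (on this read-out lower numbers stand for an effect already at smaller amounts and higher numbers for an effect only at larger amounts of compound), compound 2 `CCCCCn1c(N)nc2c(CC)cccc21` gives 1650 nM, the only number reported so far. Within the data shown here, compound 1 `CCCCCn1c(N)nc2c(Br)cccc21` carries a bromine in the same place and is reported in this assay as "not active" (no number reported), so no number stands beside it, and no step between compound 1 and compound 2 can be sized. Compound 2 therefore stands alone as the sole measured anchor for the ethyl-bearing core.

Compound 3 `CCCCCn1c(N)nc2c(-c3ccccc3)cccc21` differs from compound 2 in one place: phenyl in place of ethyl on an aromatic carbon. Among the measured compounds shown here, no measured pair shows what such a change does, so nothing about its direction can be read from the numbers in hand. The expectation is that compound 3 stays in the same region as compound 2, with a step from compound 2 to compound 3 of a 1.2-fold higher number from compound 2 to compound 3 (0.08 log units; within the scatter) that is not expected to exceed the usual scatter by much in either direction. For compound 3 the estimate in this assay is 2000 nM, with a range from 400 nM to 10000 nM; the uncertainty is wide because only compound 2 with 1650 nM supports it.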

Compound 3, half-maximal effective concentration: "not active" (no number reported)
For compound 3 the study gives words and no number; the estimate stays without a comparison.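

Within the data shown here, compound 3, like compound 1, is reported in this assay in words and without a number, so no step from compound 2 to either can be read. The compounds shown leave open how other groups on this aromatic carbon would compare with ethyl. No measurement shown accounts for the result for compound 3.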